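Lengthening the chain on compound 3

This account rests on a few compounds, and the source may have more. Where it says the series, first, only, none or still open, it means among the compounds named here.

Compound 3 (`CCn1ccc2nc(-c3ccccc3)nc-2c1`) gives > 100000 nM in an ADME assay on MDBK cells (Bos taurus) for cytotoxicity (on this read-out lower numbers stand for higher toxicity in this test and higher numbers for lower toxicity in this test), and this is a limit and not a number. Compound 1 (`c1ccc(Cn2ccc3nc(-c4ccccc4)nc-3c2)cc1`) gives > 100000 nM there, also only a limit. Compound 2 (`Brc1ccccc1Cn1ccc2nc(-c3ccccc3)nc-2c1`) gives > 100000 nM there, again only a limit. Compound 4 (`CC(C)CCn1ccc2nc(-c3ccccc3)nc-2c1`) follows from compound 3 by one change (isopropyl in place of hydrogen on a saturated chain carbon, two bonds along the chain from an aromatic nitrogen) which is isopropyl in place of hydrogen on a saturated chain carbon, two bonds along the chain from an aromatic nitrogen. Among the compounds with values here, two measured changes touch this chain (a step that the two limits leave unreadable from compound 1 to compound 3 and a step that the two limits leave unreadable from compound 2 to compound 3) and neither has a readable size, while the series rests at the limit of > 100000 nM in this assay, at which 3 of the 3 values shown sit, as its only guide. The expected step (a number no higher from compound 3 to compound 4 (the limit leaves the size open)) in this assay is therefore none beyond the scatter, in either direction. Compound 4 is estimated at 100000 nM with an expected range from 50000 nM to 200000 nM and may well turn out to be a limit again.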

Compound 4, half-maximal cytotoxic concentration: > 100000 nM
Compound 4: only a limit was reported; the forecaster's own chance of this, stated with the estimate: 85%; the middle value sits exactly at the limit.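

Compound 4 also gives only a limit, so its steps from compound 1, compound 2 and compound 3 cannot be read. The compounds shown leave open whether changing this chain shifts cytotoxicity at all, with every compound resting at one limit: the limit of > 100000 nM in this assay, at which 4 of the 4 values shown sit.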